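The compounds below may be only part of what the source reports. "The series", "measured", "known", "first", "only" and "open" are said of these compounds alone.

Measured so far:
Compound 1, `O=C1C[C@H](O)CC(CCc2ccccc2-c2ccccc2)O1`, gives 44000 nM.
Compound 2, `Cc1cccc(-c2cc(Cl)cc(Cl)c2/C=C/[C@@H]2C[C@@H](O)CC(=O)O2)c1`, gives 16 nM.
Compound 3, `Cc1cc(C)c(CCC2C[C@@H](O)CC(=O)O2)c(-c2ccc(F)c(C)c2)c1`, gives 22 nM.

In an assay for inhibition of 3-hydroxy-3-methylglutaryl-coenzyme A reductase (Rattus norvegicus) (on this read-out higher numbers stand for weaker inhibition and lower numbers for stronger inhibition), compound 2 holds the lowest of the three numbers. Its nearest neighbour is compound 3, whose number lies within the scatter of that of compound 2, so these two cannot be placed in order. Compound 1 stands far higher, well beyond the scatter.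

Compound 4, `CCc1cccc(-c2cc(Cl)cc(Cl)c2/C=C/[C@@H]2C[C@@H](O)CC(=O)O2)c1`, has not yet been measured. It differs from compound 2 by methyl in place of hydrogen on a saturated chain carbon bound to an aromatic carbon. Within the data shown here, no pair of measured compounds separated by a single change is available, so the step must be judged from the change alone: the group enters on a saturated chain carbon bound to an aromatic carbon, with the rest of the molecule unchanged from compound 2. For a change of this kind no step beyond the scatter is expected in either direction; the step of a 1.1-fold higher number from compound 2 to compound 4 (0.05 log units; within the scatter) is estimated to be small. Compound 4 is accordingly expected at 18 nM, with a range from 7 nM to 45 nM.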

Compound 4, half-maximal inhibitory concentration: 44 nM
The estimate for compound 4 lay 2.4-fold (0.39 log units) below the measured number; the range from low to high includes it.
By their numbers in this assay, from the lowest: compounds 2, 3 and 4 (each within the scatter of the next, the first and the last beyond it); then compound 1.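

In this assay, among these compounds, the pair of compound 2 and compound 4 gives the first reading of a single change: going from 3-methylphenyl to 3-ethylphenyl, with methyl in place of hydrogen on a saturated chain carbon bound to an aromatic carbon, gives a 2.8-fold higher number from compound 2 to compound 4 (0.44 log units; beyond the scatter). The position therefore responds to one added methyl, though only modestly, and compound 4 still gives 44 nM. Nothing available explains the step.

One step cannot show whether the number keeps rising with a longer chain such as propyl, or how a branched isopropyl, a methoxy or a hydroxymethyl group would read at this place. From the compounds shown here alone, it also remains open whether the same change would give a step of similar size on the core of compound 3.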